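Extending the Side Chain of a Weak Inhibitor

The source may report more compounds than this note shows. Statements on the series, on what has been measured and on what is new or still open speak of the compounds shown alone.

Compound 1 `CC(C)[C@H](NC(=O)COc1cccc2ccccc12)C(=O)N[C@@H](CC(=O)O)C(=O)CSc1ncc[nH]1`: in a functional assay on Jurkat cells (Homo sapiens) for inhibition (a lower number here means a stronger inhibitor, a higher number a weaker inhibitor), compound 1 gives a limit, > 200000 nM.
Compound 2 `CC(C)[C@H](NC(=O)COc1cccc2ccccc12)C(=O)N[C@@H](CC(=O)O)C(=O)CSC1=NCCS1`: in this assay compound 2 gives a limit, > 200000 nM.
Compound 3 `Cc1nnc(SCC(=O)[C@H](CC(=O)O)NC(=O)[C@@H](NC(=O)COc2cccc3ccccc23)C(C)C)s1`: in this assay compound 3 gives 190000 nM.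

Compound 1 sits at the limit of the assay, a limit shared by two of the three values (the limit of > 200000 nM in this assay, at which 2 of the 3 values shown sit). The step of an at least 1.0-fold lower number from compound 1 to compound 3 (0.02 log units; that floor lies within the scatter) is only a floor, and the step that the two limits leave unreadable from compound 1 to compound 2 cannot be read at all. Compound 4 `CC(C)[C@H](NC(=O)COc1cccc2ccccc12)C(=O)N[C@@H](CC(=O)O)C(=O)COn1nnc2ccccc21` carries a different group: a group of 10 heavy atoms (6 carbon, 3 nitrogen, 1 oxygen; one five-membered aromatic ring with 3 hetero atoms, one six-membered aromatic ring of carbon only) in place of a group of 6 heavy atoms (3 carbon, 2 nitrogen, 1 sulfur; one five-membered aromatic ring with 2 hetero atoms), on a saturated chain carbon bound to a carbonyl carbon. For the measured compounds named here, none of the measured steps changes the group in this way, and none of them moved the number beyond the scatter. Compound 4 is therefore expected to remain near the limit, as 200000 nM, between 50000 nM and 600000 nM. This corresponds to an expected step of a number no higher from compound 1 to compound 4 (the limit leaves the size open).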

Compound 4, half-maximal inhibitory concentration: > 200000 nM
Compound 4: no number, only a limit; the forecaster's own chance of this, stated with the estimate: 70%; the middle value lies on the limit itself.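

Exchanging the (1H-imidazol-2-yl)sulfanyl group for a larger group with two rings, on the saturated chain carbon bound to a carbonyl carbon, still leaves compound 4 at a limit in this assay. For the compounds shown here, the one readable step, an at least 1.0-fold higher number from compound 3 to compound 4 (0.02 log units; that floor lies within the scatter), is only a floor, and the steps from the other two compounds cannot be read. Even this larger group leaves the series at one limit: the limit of > 200000 nM in this assay, at which 3 of the 4 values shown sit.

From the compounds shown here alone, whether a group without a ring at this place, such as an amine or a short alkyl chain, would give a number clear of the limit stays open.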